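Replacing Chloro with Acetoxy: An Untested Step

The compounds below may be only part of what the source reports. "The series", "measured", "known", "first", "only" and "open" are said of these compounds alone.

Compound 1 `O=C(/C=C/C=C/c1ccc(Cl)cc1)N1CCCCC1` carries a chloro group on its aromatic ring. In an assay for inhibition of Polyunsaturated fatty acid 5-lipoxygenase (Homo sapiens), read by spectrophotometry, tested at 20 uM (a higher number here means more inhibition at the concentration tested (going by the name of the read-out), a lower number less inhibition), compound 1 gives 14.5%, the lowest of the three numbers in hand. Compound 3 `O=C(/C=C/C=C/C=C/c1ccc(O)c(O)c1)N1CCCCC1`, whose aromatic ring bears hydroxy groups, gives 30.3% in this assay, a number above that of compound 1 by more than the usual scatter. Compound 2 `COc1cc(/C=C/C=C/C(=O)N2CCCCC2)cc(OC)c1OC`, whose ring bears methoxy groups, gives 66.7%, the highest of the three and far beyond the scatter from compound 1.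

Compound 4 `CC(=O)Oc1ccc(/C=C/C=C/C(=O)N2CCCCC2)cc1` has not yet been measured. It differs from compound 1 in one place: acetoxy in place of chloro on an aromatic carbon. Among the measured compounds shown here, no measured pair in this set differs in exactly that way, so the size of the step has to be judged from what the other compounds show. Because compound 2 gives 66.7% and compound 3 gives 30.3%, both oxygen-bearing rings ending above the chloro-bearing compound 1, an upward step in this assay is expected, probably modest but beyond the scatter. For compound 4 the expected inhibition is 30%, with a likely range from 10% to 55%. That estimate means a step of a number 15.5 percentage points higher from compound 1 to compound 4 (beyond the scatter), expected to point upward.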

Compound 4, a percentage reported as inhibition, at one concentration (the size of the read-out at that concentration, not a potency): 18.3%
Compound 4: middle estimate off by 11.7 percentage points, on the high side; low and high end bracket the measured number.
By their numbers in this assay, from the lowest: compounds 1 and 4 (each within the scatter of the next); then compound 3; then compound 2.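

In this assay, putting acetoxy in place of chloro on an aromatic carbon, para to a large group, gives a step of a number 3.8 percentage points higher from compound 1 to compound 4 (within the scatter). Among the compounds shown here, this is the first comparison in the set between two compounds that differ in only one place, and it shows that this exchange makes no readable difference in the assay, even though one heavy atom is replaced by four and a group with no hydrogen-bond acceptors by one with two. No measurement at hand bears on why the two compounds read alike.

On these data alone, what remains open is whether any other group at this position would separate itself from chloro and acetoxy, such as an amine or a carboxylic acid on the same aromatic carbon of the core of compound 1. As far as these compounds go, it is also open whether the exchange of chloro for acetoxy would give a similarly small step on a core with a longer chain, since this one pair is the only direct view of that change.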